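Shortening the Amide Chain from Butyl to Propyl

The source may hold more compounds than are shown below. What is called first, only, known or untested is meant among the compounds shown, and "the series" means these compounds.

Three compounds have been measured in a functional assay (brain) for inhibition, with Rattus norvegicus as the target; on this read-out higher numbers stand for weaker inhibition and lower numbers for stronger inhibition:
compound 1 `COc1cc2c(cc1O)CCC(C(=O)Nc1ccccc1)O2` gives 6900 nM
compound 2 `CCCCNC(=O)C1CC(=O)c2cc(O)c(OC)cc2O1` gives 177000 nM
compound 3 `CCCCNC(=O)C1CCc2cc(O)c(OC)cc2O1` gives 51300 nM

Compound 3 stands second highest of the three numbers in this assay. Among the compounds with values here, its nearest neighbour is compound 2, which differs in the ring of the shared core; its furthest is compound 1, reached by the one step that has been measured, a 7.4-fold higher number from compound 1 to compound 3 (0.87 log units; beyond the scatter). That step shows the group on the amide-type nitrogen has a clear effect on the number: butyl in place of phenyl raised it by a modest but real amount.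

Compound 4 `CCCNC(=O)C1CCc2cc(O)c(OC)cc2O1` is the next step from compound 3: hydrogen in place of methyl on a saturated chain carbon, three bonds along the chain from an amide-type nitrogen. Within the data shown here, no measured pair shows a chain shortened by one carbon on this nitrogen, so the only guidance is that the amide substituent matters at all, as seen between compound 1 and compound 3. Because a 7.4-fold higher number from compound 1 to compound 3 (0.87 log units; beyond the scatter) moved the number when the whole group was exchanged, a smaller change within the alkyl chain is expected to move it less, if at all, in either direction. The step expected is therefore a 1.1-fold higher number from compound 3 to compound 4 (0.03 log units; within the scatter), with its range left wide. In this assay compound 4 is expected to give about 55000 nM, most likely between 18000 nM and 170000 nM.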

Compound 4, half-maximal inhibitory concentration: 119000 nM
Beside the measured number, compound 4's estimate is 2.2-fold (0.34 log units) below it, and the stated range covers the measured number.
By their numbers in this assay, from the lowest: compound 1; then compound 3; then compounds 4 and 2 (each within the scatter of the next).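

Shortening butyl to propyl, on a saturated chain carbon three bonds along the chain from an amide-type nitrogen, gives a 2.3-fold higher number from compound 3 to compound 4 (0.37 log units; beyond the scatter) in this assay and so shows that losing one carbon from this alkyl chain is enough to change the number, with no hydrogen-bond donor or acceptor entering or leaving. Measured against phenyl on the same nitrogen, propyl gives a 17-fold higher number from compound 1 to compound 4 (1.24 log units; beyond the scatter) and butyl gives a 7.4-fold higher number from compound 1 to compound 3 (0.87 log units; beyond the scatter) so the size of the gap from compound 1 depends on the length of the alkyl chain and not only on phenyl having been replaced. Nothing available here explains why the number rises when the chain is shortened.

Two chain lengths cannot show whether a longer chain such as pentyl or hexyl would bring the number further down towards that of compound 1, or whether ethyl would raise it further. From the compounds shown here alone, it also remains open whether a benzyl group, which joins a phenyl ring to the nitrogen through a single carbon, or an amine at the end of the chain would give a lower number than butyl or propyl.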